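Cytotoxicity notes on the shared core: amino to tert-butyl

This account rests on a few compounds, and the source may have more. Where it says the series, first, only, none or still open, it means among the compounds named here.

The series rests on one core, seen in compound 1 `COc1cc2c(=O)c(C(=O)c3ccc(C)cc3)cn(Cc3ccc(N)cc3)c2cc1OC`, and is read in an ADME assay on Huh-7 cells (Homo sapiens) for cytotoxicity; a lower number here means a stronger inhibitor of growth, a higher number a weaker inhibitor of growth. For compound 1 no single number stands: in this assay compound 1 is recorded as "not active" (no number reported). Two relatives carry numbers. For the measured compounds named here, compound 2 `COc1cc2c(=O)c(C(=O)c3ccc(C)cc3)cn(Cc3ccc(C(C)C)cc3)c2cc1OC` gives in this assay a value of 15500 nM, and compound 3 `COc1cc2c(=O)c(C(=O)OCc3ccccc3C)cn(Cc3ccc(C(F)(F)F)cc3F)c2cc1OC`, which differs from the others in more than one place, gives in this assay a value of 31000 nM; these two readings lie close to one another, and no step between them is worked out.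

The unmeasured member is compound 4 `COc1cc2c(=O)c(C(=O)c3ccc(C)cc3)cn(Cc3ccc(C(C)(C)C)cc3)c2cc1OC`. It differs from compound 1 by tert-butyl in place of amino on an aromatic carbon. Compound 1 offers only the outcome that no growth inhibition was reached; there is no number to build a step from, so no step size in this assay can be stated for this change. The closest measured guide is compound 2, whose isopropyl group sits at the same place as the tert-butyl of compound 4.

Resting on compound 2 and its reading of 15500 nM, compound 4 is expected to fall near 13000 nM in this assay, within roughly 5000 nM to 40000 nM.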

Compound 4, concentration for 50% growth inhibition: > 25000 nM
Compound 4 gave a limit, no number; the forecaster's own chance of this, stated with the estimate: 30%; middle value at least 1.9-fold (0.28 log units) from the limit.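

Compound 4 carries only a limit in this assay, not a number: the limit of > 25000 nM in this assay, at which 1 of the 4 values shown sits.

Read against compound 2, the change from isopropyl to tert-butyl gives an at least 1.6-fold higher number from compound 2 to compound 4 (0.20 log units; that floor lies within the scatter), so the added methyl on the saturated chain carbon brings no sign of stronger growth inhibition, while the size of any real loss stays unfixed. Compound 1 and compound 4 both lack a number, so the step for amino to tert-butyl cannot be read, and among these three close relatives only compound 2, with isopropyl, gives a number, 15500 nM.

For the compounds shown here, how far the reading of compound 4 lies beyond its limit remains open, as does whether the isopropyl reading marks a real preference at this position or only a single value close to the top of the range read so far. A carboxylic acid, a methoxy group or a longer chain such as n-butyl on the same aromatic carbon of the shared core would show how growth inhibition in this assay follows the group at this place.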